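Notes on the step from compound 2 to compound 4

The source may report more compounds than this note shows. Statements on the series, on what has been measured and on what is new or still open speak of the compounds shown alone.

Within the data shown here, in an ADME assay on WI-38 cells (Homo sapiens) for cytotoxicity, read by MTT assay, with a stated time of 72 h (a higher number here means a weaker inhibitor, a lower number a stronger inhibitor), compound 2 `O=C(CCc1cccc2c1B(O)OC2)Nc1cccc(-c2cccc(F)c2)c1` gives 37000 nM, the highest of the three numbers measured so far. Compound 3 `O=C(CCc1cccc2c1B(O)OC2)Nc1cccc(-c2cccc(OC(F)(F)F)c2)c1` is nearest at 9800 nM, and compound 1 `O=C(CCc1cccc2c1B(O)OC2)Nc1cccc2ccccc12` lies furthest away at 1200 nM.

Compound 4 `CSc1ccc(-c2cccc(NC(=O)CCc3cccc4c3B(O)OC4)c2)cc1` carries 4-(methylsulfanyl)phenyl in place of the 3-fluorophenyl of compound 2, on an aromatic carbon of a six-membered aromatic ring of carbon only, meta to a large group: 4-(methylsulfanyl)phenyl in place of 3-fluorophenyl on an aromatic carbon.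

Among the measured compounds shown here, one measured step bears on this change: a 3.8-fold lower number from compound 2 to compound 3 (0.58 log units; beyond the scatter), with trifluoromethoxy in place of fluoro on an aromatic carbon. That step is modest but beyond the scatter. For the measured compounds named here, it is the only such comparison, and no measured compound carries the 4-(methylsulfanyl)phenyl group, so the expectation stays loose. In this assay, a modest step toward a lower number is expected, estimated as a 2.6-fold lower number from compound 2 to compound 4 (0.42 log units; beyond the scatter). For compound 4 the estimated value is 14000 nM, with an expected range from 5000 nM to 40000 nM.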

Compound 4, half-maximal inhibitory concentration: 3800 nM
Compound 4: the middle estimate sits 3.7-fold (0.57 log units) above what was measured; the whole stated range lies above it.
By their numbers in this assay, from the lowest: compound 1; then compound 4; then compound 3; then compound 2.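

Working notes on the aryl position: in this assay the exchange of 3-fluorophenyl for 4-(methylsulfanyl)phenyl gives a 9.7-fold lower number from compound 2 to compound 4 (0.99 log units; beyond the scatter) and so adds a replacement of the whole aryl group to the substituent exchange seen earlier. With a 3.8-fold lower number from compound 2 to compound 3 (0.58 log units; beyond the scatter) as the other listed step from compound 2, both changes at this position lower the number, and neither of the two compounds goes against that direction. No measurement available here explains the direction or size of either step.

The change from compound 2 to compound 4 alters both the substituent and its place on the ring, so the contribution of each stays unresolved. Also open, on these data alone, is how 3-(methylsulfanyl)phenyl, or a phenyl ring carrying an amine or a carboxylic acid, would read at this aromatic carbon.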